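Methylsulfanyl in Place of Methyl on One Scaffold

The source may hold more compounds than are shown below. What is called first, only, known or untested is meant among the compounds shown, and "the series" means these compounds.

Of the compounds shown here, three built on a shared core have been tested in an ADME assay on SW480 cells (Homo sapiens) for cytotoxicity, read by MTT assay, with a stated time of 72 h; on this read-out higher numbers stand for weaker inhibition and lower numbers for stronger inhibition. Compound 1 `CCCCCN1C(=O)C/C(=C\c2cccc(C(=O)Nc3ccc(C)cc3)c2)C1=O` reaches only the limit of the assay, > 100000 nM. Compound 2 `Cc1cccc(NC(=O)c2cccc(/C=C3\CC(=O)N(c4ccccc4)C3=O)c2)c1` likewise gives only a limit, > 100000 nM. Compound 3 `CCCCNC(=O)c1cccc(/C=C2\CC(=O)N(Cc3ccccc3)C2=O)c1` also stops at a limit, > 100000 nM. Compound 2 therefore stands exactly where every value shown sits, namely (the limit of > 100000 nM in this assay, at which 3 of the 3 values shown sit). For the measured compounds named here, no step between measured compounds can be read from these limits. Compound 4 `CSc1cccc(NC(=O)c2cccc(/C=C3\CC(=O)N(c4ccccc4)C3=O)c2)c1` differs from compound 2 in one place: methylsulfanyl in place of methyl on an aromatic carbon. Given that compound 2 shows only a limit in this assay, no step beyond the scatter is expected, and the change from compound 2 to compound 4 is estimated as a step that the limit leaves unreadable from compound 2 to compound 4. Compound 4 is expected at 200000 nM, within 60000 nM to 1000000 nM.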

Compound 4, half-maximal inhibitory concentration: 74300 nM
For compound 4 the middle estimate is 2.7-fold (0.43 log units) above the measured one, and the stated range covers the measured number.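

In this assay compound 4 is the first compound shown to give a true number, 74300 nM, so a change at this aromatic carbon can bring the read-out inside the range of the assay. Methylsulfanyl in place of methyl gives an at least 1.3-fold lower number from compound 2 to compound 4 (0.12 log units; that floor lies within the scatter); this is only a floor, so the real step may be larger or may stay within the scatter. Compound 2 has only a limit, so the full step cannot be read: the limit of > 100000 nM in this assay, at which 3 of the 4 values shown sit.

On these data alone, what a methoxy group, a chlorine atom or the longer ethylsulfanyl group would do on this same carbon remains open.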